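This account rests on a few compounds, and the source may have more. Where it says the series, first, only, none or still open, it means among the compounds named here.

Measured so far:
compound 1 `Clc1cccc(-n2cc(CNc3ccc(-c4nc5ccccc5s4)cc3)nn2)c1`, 200 nM
compound 2 `O=C(CN1CCN(c2ccccc2)CC1)Nc1ccc(-c2nc3ccccc3s2)cc1`, 200 nM

In a functional assay on HeLa cells (Homo sapiens) for inhibition (a lower number here means a stronger inhibitor of growth, a higher number a weaker inhibitor of growth), compound 1 gives 200 nM. In this assay compound 2 gives 200 nM. The two values stand level at the digits shown, the gap within the usual scatter, so no order between compound 1 and compound 2 can be read. Going by the values given here, the two compounds differ in more than one place, so no single-point step can be taken from the measured pair.

The next compound, compound 3 `COc1cccc(-n2cc(CNc3ccc(-c4nc5ccccc5s4)cc3)nn2)c1`, is to be measured in this assay. It differs from compound 1 by methoxy in place of chloro on an aromatic carbon. Among the compounds with values here, no measured pair shows this exchange, so the size of the step rests on no data of this series. The expectation is a step no larger than the scatter, if anything toward a weaker inhibitor. The expected step is a 1.3-fold higher number from compound 1 to compound 3 (0.10 log units; within the scatter). For compound 3 the estimated value in this assay is 250 nM, with a range from 100 nM to 700 nM.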

Compound 3, concentration for 50% growth inhibition: 200 nM
Compound 3: middle estimate off by 1.3-fold (0.10 log units), on the high side; the measured number falls inside the stated range.
By their numbers in this assay, from the lowest: compounds 1, 2 and 3 (each within the scatter of the next).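

In this assay, going by these compounds alone, methoxy in place of chloro on this aromatic carbon gives no change at the digits printed from compound 1 to compound 3 (within the scatter), the first step that changes a single place. This position therefore carries either chloro, with 1 heavy atom and 0 hydrogen-bond acceptors, or methoxy, with 2 heavy atoms and 1 hydrogen-bond acceptor, with no readable difference in growth inhibition, though this rests on one pair only. No evidence is available that bears on this result.

Going by these compounds, whether the same holds for an amine, a carboxylic acid or a longer chain at this position stays open. Also open, on these data alone, is how the number responds to changes elsewhere in the core of compound 1, since this single step covers only the 3-chlorophenyl to 3-methoxyphenyl exchange.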